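A few compounds are considered here, and "the series" means these few. Any claim that something is new, unique, unknown or untested is made for them only; others in the source may bear on it.

Compound 1, `Nc1cc(N)c2nc(-c3ccccc3)c(Oc3ccc(Cl)c(Cl)c3)nc2c1`, gives 33900 nM in a functional assay on Hs-578T cells (Homo sapiens) for inhibition, read by sulforhodamine B assay, with a stated time of 48 h; on this read-out lower numbers stand for stronger inhibition of growth and higher numbers for weaker inhibition of growth. Compound 2, `Nc1cc(N)c2nc(-c3ccccc3)c(Sc3ccc(Cl)c(Cl)c3)nc2c1`, gives in this assay only the assay limit < 100000 nM.

Compound 2 therefore stands at a limit and not at a number in this assay, so the step that the limit leaves unreadable from compound 1 to compound 2 cannot be read because of the limit of < 100000 nM in this assay, at which 1 of the 2 values shown sits. Compound 3, `Nc1cc(N)c2nc(-c3ccccc3)c(Sc3ccc(F)cc3)nc2c1`, differs from compound 2 by 4-fluorophenyl in place of 3,4-dichlorophenyl on a sulfur. Going by the values given here, no measured step bears on this change: the only measured step is the unreadable one just named, and compound 1 offers the single number that anchors the series. The expectation for compound 3 in this assay is therefore loosely held, with a wide range and a real chance that only a limit is reported. Compound 3 is estimated at 40000 nM, within a range from 8000 nM to 100000 nM. This estimate means an expected step that the limit leaves unreadable from compound 2 to compound 3.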

Compound 3, concentration for total growth inhibition: 61700 nM
Beside the measured number, compound 3's estimate is 1.5-fold (0.19 log units) below it; the range from low to high includes it.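

Going by these compounds alone, compound 3 gives the first number for a compound with a sulfanyl group at this aromatic carbon in this assay. Against compound 1, the change to (4-fluorophenyl)sulfanyl from 3,4-dichlorophenoxy gives a 1.8-fold higher number from compound 1 to compound 3 (0.26 log units; within the scatter), so this replacement, which alters both the linking atom and the ring on it, shows no change that can be told from scatter. Compound 2 stands at a limit, so the steps that involve it, including the change from 3,4-dichlorophenyl to 4-fluorophenyl on a sulfur, cannot be read: the limit of < 100000 nM in this assay, at which 1 of the 3 values shown sits.

The compounds shown leave open how a sulfur link alone compares with an oxygen link when both carry the same ring and both give a number. Also open, as far as these compounds go, is what an amine or a carboxylic acid on that ring, or a longer chain in place of the ring on the sulfur, would give in this assay.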